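The source may hold more compounds than are shown below. What is called first, only, known or untested is meant among the compounds shown, and "the series" means these compounds.

Compound 3 `Cc1nnn(Cc2ccc(C(F)(F)F)cc2)c1C(=O)N[C@@H](C)c1ccc(C(=O)O)cc1` carries a methyl group on the shared core. In a functional assay on CHO cells for antagonist activity at prostaglandin E2 receptor EP4 subtype (Homo sapiens), read by calcium flux, with a stated time of 15 min (on this read-out lower numbers stand for stronger inhibition and higher numbers for weaker inhibition), compound 3 gives > 10000 nM, which is a limit of the assay and not a number, as noted under (the limit of > 10000 nM in this assay, at which 1 of the 3 values shown sits). For comparison, compound 1 `C[C@H](NC(=O)c1c(C(F)(F)F)nnn1Cc1cccc(C(F)(F)F)c1)c1ccc(C(=O)O)cc1` gives 1970 nM in this assay, and compound 2 `C[C@H](NC(=O)c1c(C(F)(F)F)nnn1CCOc1ccc(F)cc1)c1ccc(C(=O)O)cc1` gives 276 nM. Among the measured compounds shown here, the only single-point step among the measured compounds, a 7.1-fold lower number from compound 1 to compound 2 (0.85 log units; beyond the scatter), concerns the group on the saturated chain carbon bound to the aromatic nitrogen and not the position changed here. Compound 4 `C[C@H](NC(=O)c1c(C2=CCCCC2)nnn1Cc1ccc(C(F)(F)F)cc1)c1ccc(C(=O)O)cc1` differs from compound 3 by cyclohex-1-en-1-yl in place of methyl on an aromatic carbon. For the measured compounds named here, no measured step addresses this position; compound 1 and compound 3 differ there and at a second place, so their two values give only a loose hint that a group larger than methyl on that ring carbon may go with a lower number. Compound 4 is therefore expected to move down from the limit, an at least 5.0-fold lower number from compound 3 to compound 4 (0.69 log units; beyond the scatter), with wide uncertainty. The estimate for compound 4 is 2000 nM, between 300 nM and 10000 nM.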

Compound 4, half-maximal inhibitory concentration: 183 nM
Beside the measured number, compound 4's estimate is 11-fold (1.04 log units) above it; measured number below the stated range.
By their numbers in this assay, from the lowest: compounds 4 and 2 (each within the scatter of the next); then compound 1. At a limit, above all of these: compound 3.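

Compound 3 gives > 10000 nM in this assay, which is a limit of the assay and not a number: the limit of > 10000 nM in this assay, at which 1 of the 4 values shown sits. Among the compounds shown here, the change gives the first direct reading of this aromatic carbon, next to the ring nitrogen: an at least 54-fold lower number from compound 3 to compound 4 (1.73 log units; beyond the scatter), a large step beyond the scatter. So this position accepts cyclohex-1-en-1-yl, with its six carbons in one non-aromatic ring, and replacing methyl with it goes with a much lower number on this read-out.

The compounds shown leave open whether the ring, its double bond or simply the added carbons go with this step; cyclohexyl, phenyl or a short open carbon chain at this position would separate these. From the compounds shown here alone, it also remains open how an amine or an ether oxygen on this carbon would read.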